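Trifluoromethyl in place of nitro on the hydrazone aryl

The source may hold more compounds than are shown below. What is called first, only, known or untested is meant among the compounds shown, and "the series" means these compounds.

Measured compounds:
compound 1 `CN(C(=O)NC(=O)c1ccccc1F)c1nc(C(F)(F)F)c(C(=O)N/N=C/c2ccc(C(F)(F)F)cc2)s1`: 5.68 ug/mL
compound 2 `CN(C(=O)NC(=O)c1ccc(Cl)cc1Cl)c1nc(C(F)(F)F)c(C(=O)N/N=C/c2ccc(C(F)(F)F)cc2)s1`: 9.4 ug/mL
compound 3 `CN(C(=O)NC(=O)c1ccc(F)c(F)c1)c1nc(C(F)(F)F)c(C(=O)N/N=C/c2ccc([N+](=O)[O-])cc2)s1`: 5.78 ug/mL

All three were tested in a functional assay on A549 cells (Homo sapiens) for inhibition, read by MTT assay, with a stated time of 72 h; a lower number here means a stronger inhibitor, a higher number a weaker inhibitor. In this assay compound 3 gives 5.78 ug/mL, the second highest of the three numbers, while compound 1 gives 5.68 ug/mL and compound 2 gives 9.4 ug/mL, both within the scatter of compound 3. Within the data shown here, the only measured step, a 1.7-fold higher number from compound 1 to compound 2 (0.22 log units; within the scatter), lies within the scatter and alters the group on a carbonyl carbon, not the hydrazone aryl. Compound 4 `CN(C(=O)NC(=O)c1ccc(F)c(F)c1)c1nc(C(F)(F)F)c(C(=O)N/N=C/c2ccc(C(F)(F)F)cc2)s1` differs from compound 3 in one place: trifluoromethyl in place of nitro on an aromatic carbon. Among the measured compounds shown here, no measured step covers this change. The step of a 1.0-fold higher number from compound 3 to compound 4 (0.02 log units; within the scatter) is therefore expected to stay within the scatter, in no set direction. Compound 4 is estimated at 6 ug/mL, ranging from 3 ug/mL to 12 ug/mL.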

Compound 4, half-maximal inhibitory concentration: 6.07 ug/mL
For compound 4 the middle estimate is 1.0-fold (0.01 log units) below the measured one; the range from low to high includes it.
By their numbers in this assay, from the lowest: compounds 1, 3, 4 and 2 (each within the scatter of the next).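

Among these compounds, the pair gives the first direct reading at the hydrazone aryl: in this assay the exchange of nitro for trifluoromethyl is a 1.1-fold higher number from compound 3 to compound 4 (0.02 log units; within the scatter), so the two groups cannot be told apart at this position. Compound 4 also links the aryl groups on the carbonyl carbon, with a 1.5-fold lower number from compound 2 to compound 4 (0.19 log units; within the scatter) and a 1.1-fold higher number from compound 1 to compound 4 (0.03 log units; within the scatter), and neither exchange separates the compounds. No evidence is available that would explain these results. On these data alone, whether an amine or a carboxylic acid in this place would read differently remains open.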